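Fluoro for hydrogen, repeated on two related cores

The source may report more compounds than this note shows. Statements on the series, on what has been measured and on what is new or still open speak of the compounds shown alone.

Compound 1 `N/C(=N\NC(=S)N1CCCCCC1)c1ccccn1` and compound 2 `N/C(=N\NC(=S)N1CCSCC1)c1ccccn1` differ in their cores; that difference is not broken down here. In a functional assay on A-375 cells (Homo sapiens) for cytotoxicity, read by MTT assay, with a stated time of 72 h, tested at 30 uM (a lower number here means less inhibition of growth, a higher number more inhibition of growth at the concentration tested), compound 1 gives 90% and compound 2 gives 86%, two numbers within the scatter of each other. Compound 3 `N/C(=N\NC(=S)N1CCSCC1)c1ccc(F)cn1` is compound 2 after one change, (fluoro in place of hydrogen on an aromatic carbon). In this assay compound 3 gives 78.7%, a step of a number 7.3 percentage points lower from compound 2 to compound 3 (within the scatter). Compound 4 `N/C(=N\NC(=S)N1CCCCCC1)c1ccc(F)cn1` is compound 1 after the same change, (fluoro in place of hydrogen on an aromatic carbon); the place of entry is identical in both cases, and the change occurs two times in this set. Going by the values given here, the expected step from compound 1 is a number 7 percentage points lower from compound 1 to compound 4 (within the scatter), resting on the single measured instance a number 7.3 percentage points lower from compound 2 to compound 3 (within the scatter). Compound 4 is therefore estimated at 83%, between 72% and 93%.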

Compound 4, percent growth inhibition at one concentration: 80%
The estimate for compound 4 lay 3 percentage points above the measured number, within the range that was stated.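

In this assay, fluoro in place of hydrogen on an aromatic carbon gives a step of a number 10 percentage points lower from compound 1 to compound 4 (within the scatter). Set beside the earlier case, the change carries across these two cores without a difference that can be read: the same change on two cores in this assay, a number 7.3 percentage points lower (within the scatter) from compound 2 to compound 3 and a number 10 percentage points lower (within the scatter) from compound 1 to compound 4, 2.7 percentage points apart, within the scatter of two such steps This shows only that the step is similar on the two cores; each step lies within the scatter, so neither establishes an effect of the fluoro itself, and two cores say nothing about others in the series.

Open, from the compounds shown here alone, is whether a chloro, a methoxy or an amine at the same place on the ring would give a step beyond the scatter. Also open, going by these compounds, is whether the two cores would still behave alike with such groups.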